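Pyridin-2-yl in place of pyridin-3-yl

The source may report more compounds than this note shows. Statements on the series, on what has been measured and on what is new or still open speak of the compounds shown alone.

In an ADME assay on microsomes from liver (Homo sapiens) for metabolic stability (a lower number here means slower removal, a higher number faster removal of the compound), compound 2 (`CN1C(=O)C2=C(C1=O)N(CC(=O)Nc1ccc(-c3cccnc3)cc1)CCC2`) gives 37 mL.min-1.g-1, within the scatter of compound 1 (`CN1C(=O)C2=C(C1=O)N(CC(=O)Nc1ccc(-c3ccncc3)cc1)CCC2`), which gives 31 mL.min-1.g-1. Going by the values given here, these two values are the only measurements so far, and they cannot be separated. Compound 3 (`CN1C(=O)C2=C(C1=O)N(CC(=O)Nc1ccc(-c3ccccn3)cc1)CCC2`) has not yet been measured. It carries pyridin-2-yl in place of pyridin-3-yl on an aromatic carbon, para to a large group: pyridin-2-yl in place of pyridin-3-yl on an aromatic carbon. Among the compounds with values here, one measured step bears on this change, the exchange of pyridin-4-yl for pyridin-3-yl at the same place, which gave a 1.2-fold higher number from compound 1 to compound 2 (0.08 log units; within the scatter). A single step is a thin guide, but on this evidence no change beyond the scatter is expected in this assay, and no direction can be favoured. The expected step is a 1.1-fold lower number from compound 2 to compound 3 (0.02 log units; within the scatter). For compound 3 the estimated value is 35 mL.min-1.g-1, with an expected range from 18 mL.min-1.g-1 to 70 mL.min-1.g-1.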

Compound 3, intrinsic clearance in microsomes: 28 mL.min-1.g-1
Compound 3: the middle estimate sits 1.3-fold (0.10 log units) above what was measured, and the stated range covers the measured number.
By their numbers in this assay, from the lowest: compounds 3, 1 and 2 (each within the scatter of the next).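

In this assay the change to pyridin-2-yl gives a 1.3-fold lower number from compound 2 to compound 3 (0.12 log units; within the scatter) and also a 1.1-fold lower number from compound 1 to compound 3 (0.04 log units; within the scatter) so the third way of attaching the pyridine ring at this place, on an aromatic carbon para to a large group, joins the other two within the scatter. Where the earlier pair showed only that pyridin-3-yl and pyridin-4-yl could not be separated, compound 1, compound 2 and compound 3 now show that the attachment point of this ring does not separate any of the three in this read-out. Nothing available offers an explanation for this result.

The compounds shown leave open whether a different group at this place, such as an unsubstituted phenyl ring, a morpholine or a carboxylic acid, would move the number beyond the scatter. They also leave open what a methyl group or a fluorine on the pyridine ring itself would do.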